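Adding a Second Chloro to a Urea-Bearing Cytotoxic Series

The source may hold more compounds than are shown below. What is called first, only, known or untested is meant among the compounds shown, and "the series" means these compounds.

Measured in a functional assay on NCI-H460 cells (Homo sapiens) for cytotoxicity, read by MTT assay, with a stated time of 72 h; a higher number here means a weaker inhibitor, a lower number a stronger inhibitor:
- compound 1 `CN(C)CCNc1nc(-c2ccc(NC(=O)Nc3ccccc3)cc2)nc2ccsc12` gives 640 nM
- compound 2 `CN(C)CCNc1nc(-c2ccc(NC(=O)Nc3ccccc3Cl)cc2)nc2ccsc12` gives 230 nM
- compound 3 `CN(C)CCNc1nc(-c2ccc(NC(=O)Nc3ccccc3Cl)cc2)nc2c(Cl)c(Cl)sc12` gives 440 nM

Compounds 1 and 2 share a core. The change between them is chloro in place of hydrogen on an aromatic carbon, and the step was a 2.8-fold lower number from compound 1 to compound 2 (0.44 log units; beyond the scatter). Compound 3 sits on a different core; the difference between the two cores is not broken down here.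

Compound 4 `CN(C)CCNc1nc(-c2ccc(NC(=O)Nc3ccc(Cl)cc3Cl)cc2)nc2c(Cl)c(Cl)sc12` is not yet measured. It differs from compound 3 by chloro in place of hydrogen on an aromatic carbon. The surroundings are not identical: in the earlier change the chloro sits ortho to a large group, whereas here it sits meta to a chloro group and para to a large group, so this is the same kind of change, not the same.

Because the earlier step was a 2.8-fold lower number from compound 1 to compound 2 (0.44 log units; beyond the scatter) and compound 3 stands at 440 nM, compound 4 is expected to show a 1.5-fold lower number from compound 3 to compound 4 (0.17 log units; within the scatter). The estimate for compound 4 is 300 nM, expected to fall between 120 nM and 800 nM.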

Compound 4, half-maximal inhibitory concentration: 1520 nM
The estimate for compound 4 lay 5.1-fold (0.70 log units) below the measured number; the measured number lies above the stated range.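

In this assay, adding the chloro gave a 3.5-fold higher number from compound 3 to compound 4 (0.54 log units; beyond the scatter), so the gain seen on the core of compound 1 did not carry over and the two steps run in opposite directions: the same change on two cores in this assay, a 2.8-fold lower number (0.44 log units; beyond the scatter) from compound 1 to compound 2 and a 3.5-fold higher number (0.54 log units; beyond the scatter) from compound 3 to compound 4, 9.6-fold (0.98 log units) apart, beyond the scatter of two such steps

Among these compounds, then, neither the size nor the direction of this change can be taken from one core to the other. This does not show whether the core or the place of the chloro decides the outcome, as the two vary together: in compound 4 the new chloro sits meta to a chloro group and para to a large group.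

Still open, as far as these compounds go, is what the 2,4-dichlorophenyl group does on the core of compound 1. Also open, from the compounds shown here alone, is whether a fluoro or a methoxy group in place of the added chloro would move the number the same way.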